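Working notes: from compound 3 to compound 4

This account rests on a few compounds, and the source may have more. Where it says the series, first, only, none or still open, it means among the compounds named here.

Measured in a functional assay on MCF7 cells (Homo sapiens) for antiproliferative activity, read by MTT assay, with a stated time of 72 h; a lower number here means a stronger inhibitor, a higher number a weaker inhibitor:
compound 1 `CCN1CCN(c2cc(C)c3cc(NC(=O)c4ccc(F)cc4)ccc3n2)CC1`: 4030 nM
compound 2 `CCN1CCN(c2cc(C)c3cc(NC(=O)c4ccccc4)ccc3n2)CC1`: 14200 nM
compound 3 `CCN1CCN(c2cc(C)c3cc(NC(=O)c4ccccc4Br)ccc3n2)CC1`: 27500 nM

Compound 3 cannot be separated from compound 2, the measured change being a 1.9-fold higher number from compound 2 to compound 3 (0.29 log units; within the scatter). Compound 1 stands apart from both, with a 3.5-fold higher number from compound 1 to compound 2 (0.55 log units; beyond the scatter) and a 6.8-fold higher number from compound 1 to compound 3 (0.83 log units; beyond the scatter).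

The unmeasured compound 4 `CCN1CCN(c2cc(C)c3cc(NC(=O)c4ccc5ccccc5n4)ccc3n2)CC1` has quinolin-2-yl in place of 2-bromophenyl on a carbonyl carbon. Among the measured compounds shown here, all three measured steps alter the group on that carbonyl carbon, so they are the only guide, but none of them involves quinolin-2-yl. For the measured compounds named here, their sizes run from within the scatter to modest, and no large step has been seen in this small set.

With compound 3 at 27500 nM and compound 1 at 4030 nM, a lower number is the more likely direction in this assay, and a modest step is expected, similar in size to a 3.5-fold higher number from compound 1 to compound 2 (0.55 log units; beyond the scatter). A result within the scatter of compound 3 remains possible. The estimated change is a 2.5-fold lower number from compound 3 to compound 4 (0.40 log units; beyond the scatter). For compound 4 the expected value is 11000 nM, with an estimated range of 3500 nM to 30000 nM.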

Compound 4, half-maximal inhibitory concentration: 7060 nM
Estimate against measurement, compound 4: 1.6-fold (0.19 log units) above; the measured number falls inside the stated range.
By their numbers in this assay, from the lowest: compounds 1, 4, 2 and 3 (each within the scatter of the next, the first and the last beyond it).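

In this assay, the carbonyl carbon carries a group of two aromatic rings, quinolin-2-yl, and the only group shown with a ring nitrogen and a hydrogen-bond acceptor, without any loss against the smaller aryl groups: the exchange for 2-bromophenyl gives a 3.9-fold lower number from compound 3 to compound 4 (0.59 log units; beyond the scatter). The exchange for phenyl gives a 2.0-fold lower number from compound 2 to compound 4 (0.30 log units; within the scatter), and that for 4-fluorophenyl gives a 1.8-fold higher number from compound 1 to compound 4 (0.24 log units; within the scatter), both within the scatter, so the new group cannot be told apart from either of these two aryl groups, even though they are separated from each other by a step beyond the scatter. No measurement offers an explanation for these steps.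

The set leaves open whether the ring nitrogen or the second aromatic ring matters more here, a question that pyridin-2-yl and naphthalen-2-yl on the same carbonyl carbon would separate. It also leaves open how this position responds to groups other than aromatic rings, such as a saturated piperidine ring or a carboxylic acid on an alkyl chain.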